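Dropping the methoxy from a carbamate selenocyanate

This account rests on a few compounds, and the source may have more. Where it says the series, first, only, none or still open, it means among the compounds named here.

Measured compounds:
compound 1, `COc1ccc(OC(=O)Nc2ccc([Se]C#N)cc2)cc1`, 25200 nM
compound 2, `CCCCCCOC(=O)Nc1ccc([Se][Se]c2ccc(NC(=O)OCCCCCC)cc2)cc1`, 10 nM
compound 3, `N#C[Se]c1ccc(NC(=O)OCc2ccc([N+](=O)[O-])cc2)cc1`, 7700 nM

The three compounds were tested in an ADME assay on BEAS-2B cells (Homo sapiens) for cytotoxicity, read by MTT assay, with a stated time of 72 h; a higher number here means a weaker inhibitor of growth, a lower number a stronger inhibitor of growth. Among them compound 1 gives the highest number, 25200 nM. Its nearest neighbour is compound 3, whose value of 7700 nM lies below it by a gap beyond the usual scatter. Compound 2 stands far away with 10 nM, a gap of a wholly different order. No pair of these compounds differs in only one place, so none of the gaps can be tied to a single change.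

Compound 4, `N#C[Se]c1ccc(NC(=O)Oc2ccccc2)cc1`, has not been measured. It differs from compound 1 as follows: hydrogen in place of methoxy on an aromatic carbon. A small group leaves and nothing replaces it, and the shared core keeps the carbamate and the selenocyanate. The step expected from this change, a 1.3-fold lower number from compound 1 to compound 4 (0.10 log units; within the scatter), is estimated to be small, probably within the scatter or at most a modest drop in the number. Compound 4 is therefore expected to give about 20000 nM, with a likely range from 8000 nM to 50000 nM.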

Compound 4, concentration for 50% growth inhibition: 8900 nM
The estimate for compound 4 lay 2.2-fold (0.35 log units) above the measured number; the measured number falls inside the stated range.
By their numbers in this assay, from the lowest: compound 2; then compounds 3 and 4 (each within the scatter of the next); then compound 1.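

Within the data shown here, the first comparison in one place comes in this assay, with hydrogen in place of methoxy on an aromatic carbon, para to a large group, and it gives a 2.8-fold lower number from compound 1 to compound 4 (0.45 log units; beyond the scatter). The methoxy at this position therefore has a modest but readable bearing on the number, since the step lies beyond the scatter while the carbamate and the selenocyanate stay unchanged. No measurement at hand explains why the number moves in this direction.

The compounds shown leave open whether any group at this carbon would raise the number as methoxy does, or whether that holds for methoxy alone; an amine, a chlorine or a longer ether chain there would test this. They also leave open whether the same step would appear on another core.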